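The compounds below may be only part of what the source reports. "The series", "measured", "known", "first", "only" and "open" are said of these compounds alone.

Compound 1 `CCc1ccc(-n2nc(-c3ccc(C(F)(F)F)cc3O)nc2-c2ccccc2O)cc1` gives 64.4% in a functional assay on PC-12 cells (Rattus norvegicus) for cytotoxicity, read by MTT assay, with stated times of 2 h and 24 h, tested at 1 uM; on this read-out higher numbers stand for a stronger effect at the one concentration tested and lower numbers for a weaker effect.
Compound 2 `N#Cc1ccc(-n2nc(-c3ccc(C(F)(F)F)cc3O)nc2-c2ccccc2O)cc1` gives 66.6% in this assay.
Compound 3 `Oc1cc(C(F)(F)F)ccc1-c1nc(-c2ccccc2O)n(-c2ccccc2Cl)n1` gives 70.1% in this assay.

All three compounds share the same core and differ only in the aryl group on the aromatic nitrogen. For the measured compounds named here, the measured steps are a number 2.2 percentage points higher from compound 1 to compound 2 (within the scatter), a number 5.7 percentage points higher from compound 1 to compound 3 (within the scatter) and a number 3.5 percentage points higher from compound 2 to compound 3 (within the scatter), so the three numbers lie within the scatter of one another, and no compound can be called stronger or weaker than another on this evidence.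

Compound 4 `COc1ccccc1-n1nc(-c2ccc(C(F)(F)F)cc2O)nc1-c1ccccc1O` is not yet measured. It differs from compound 3 by methoxy in place of chloro on an aromatic carbon. The steps from compound 1 and from compound 2 to compound 3 bear on this, since each also changed the aryl group on the aromatic nitrogen; both stayed within the scatter, and so did the exchange of cyano for ethyl on an aromatic carbon. Nothing in these steps points to a change in either direction in this assay beyond the scatter.

Compound 4 is therefore expected to give about 69%, with a range from 58% to 80%. The expected step from compound 3 is a number 1.1 percentage points lower from compound 3 to compound 4 (within the scatter), within the scatter.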

Compound 4, a percentage reported as activity, at one concentration (the size of the read-out at that concentration, not a potency): 70.7%
For compound 4 the middle estimate is 1.7 percentage points below the measured one, and the stated range covers the measured number.
By their numbers in this assay, from the lowest: compounds 1, 2, 3 and 4 (each within the scatter of the next).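

For the compounds shown here, compounds 1, 2 and 3 differed in the whole aryl group on the aromatic nitrogen, whereas compound 4 is the first case in which only the substituent changes at a single site, on an aromatic carbon ortho to a large group. In this assay, putting methoxy in place of chloro at this site gives a step (a number 0.6 percentage points higher from compound 3 to compound 4 (within the scatter)) that stays within the scatter, so the two groups cannot be told apart here. The 2-methoxyphenyl group likewise cannot be separated from the groups on the other two compounds (a number 4.1 percentage points higher from compound 2 to compound 4 (within the scatter); a number 6.3 percentage points higher from compound 1 to compound 4 (within the scatter)), and no measurement shown offers an explanation for any of these results.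

From the compounds shown here alone, it remains open whether an amine or a carboxylic acid in place of the chloro, or a longer chain such as butoxy in place of the methoxy, would give a step beyond the scatter. Because each compound is shown at a single concentration, these numbers also leave open how the compounds compare in potency.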